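Acid dissociation across a pair of aminoquinoline amines

This account rests on a few compounds, and the source may have more. Where it says the series, first, only, none or still open, it means among the compounds named here.

Of the compounds shown here, two have been measured in a physicochemical assay for acid dissociation. Compound 1 `COc1cccc(CNCCCNc2ccnc3cc(-c4ccc(C(C)(C)C)cc4)ccc23)c1O` gives 9.47 in this assay. Compound 2 `COc1cccc(Oc2ccc3c(NCCCNCc4ccco4)ccnc3c2)c1` gives 9.28 in this assay, and on these two numbers compound 2 sits within the scatter of compound 1, so the pair cannot be ordered on the values shown.

Compound 3 `COc1cccc(Oc2ccc3c(NCCCNCc4cccc(OC)c4O)ccnc3c2)c1` has not yet been measured in this assay. It differs from compound 2 in a single place: 2-hydroxy-3-methoxyphenyl in place of furan-2-yl on a saturated chain carbon bound to an amine nitrogen. The group that enters is the same 2-hydroxy-3-methoxybenzyl that compound 1 carries on its amine, while the rest of compound 3 is the core of compound 2.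

Within the data shown here, no measured pair shows this change directly. The value of compound 3 is expected to lie near that of compound 1 because compound 1 carries the same 2-hydroxy-3-methoxybenzyl and gives 9.47 in this assay. The step of a number 0.17 log units higher from compound 2 to compound 3 (within the scatter) is therefore expected to be small and not beyond the scatter. For compound 3 the estimate in this assay is 9.45, with a range from 9.15 to 9.75.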

Compound 3, acid dissociation constant: 9.28
Beside the measured number, compound 3's estimate is 0.17 log units above it; low and high end bracket the measured number.
By their numbers in this assay, from the lowest: compounds 2, 3 and 1 (each within the scatter of the next).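

In this assay, among these compounds, the first direct pair at this place reads no change at the digits printed from compound 2 to compound 3 (within the scatter), so on a saturated chain carbon bound to an amine nitrogen, 2-hydroxy-3-methoxyphenyl and furan-2-yl cannot be told apart. That holds even though the two groups differ in ring type and in count, with 1 hydrogen-bond donor on the entering group and 0 on the leaving one. The result also gives a second one-place pair, at an aromatic carbon, where 3-methoxyphenoxy in place of 4-(tert-butyl)phenyl gives a number 0.19 log units lower from compound 1 to compound 3 (within the scatter), so neither exchange yields a step beyond the scatter in these compounds.

Going by these compounds, it remains open whether a carboxylic acid or a second amine on the saturated chain carbon, or a longer chain carrying the amine nitrogen, would give a step beyond the scatter. The compounds shown also do not separate the hydroxy from the methoxy within the entering group, and a plain benzyl would be needed to read either one alone. Among the compounds shown here, nothing measured so far accounts for these values sitting so close together.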